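Replacing the methyl on the amide carbonyl with an aromatic ring

The source may hold more compounds than are shown below. What is called first, only, known or untested is meant among the compounds shown, and "the series" means these compounds.

Measured so far:
- compound 1, `CC(=O)Nc1cccc(NC(=O)COc2ccc3c(=O)ccoc3c2)c1`: 2500 nM
- compound 2, `Cc1cc(C(=O)Nc2cccc(NC(=O)COc3ccc4c(=O)ccoc4c3)c2)ccc1C(F)(F)F`: 460 nM

Among the compounds with values here, in an assay on isolated protein for inhibition of Rho-associated protein kinase 1 (Homo sapiens), read by scintillation counting, radiometric assay and 33P incorporation, with a stated time of 40 min, in the presence of a further agent that is not named here (a higher number here means a weaker inhibitor, a lower number a stronger inhibitor), compound 1 gives 2500 nM, the highest of the two numbers known here. Within the data shown here, compound 2 gives 460 nM, and the only measured step is a 5.4-fold lower number from compound 1 to compound 2 (0.74 log units; beyond the scatter), in which an aromatic ring takes the place of a single carbon on the carbonyl carbon.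

Compound 3, `CC(C)(C)c1cc(C(=O)Nc2cccc(NC(=O)COc3ccc4c(=O)ccoc4c3)c2)no1`, has not yet been measured. It differs from compound 1 as follows: 5-(tert-butyl)-1,2-oxazol-3-yl in place of methyl on a carbonyl carbon

Among the measured compounds shown here, the change in compound 3 is of the same kind as the one measured step: a small methyl on the carbonyl carbon gives way to a larger ring-bearing group. For the measured compounds named here, that one step is therefore the only guide, and it was modest. A similar modest gain is expected here, since the earlier ring brought a lower number, because a 5.4-fold lower number from compound 1 to compound 2 (0.74 log units; beyond the scatter). For compound 3 the estimated value in this assay is 600 nM, with a likely range from 150 nM to 2500 nM. The expected step is a 4.2-fold lower number from compound 1 to compound 3 (0.62 log units; beyond the scatter).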

Compound 3, half-maximal inhibitory concentration: 101 nM
Estimate against measurement, compound 3: 5.9-fold (0.77 log units) above; the measured number lies below the stated range.
By their numbers in this assay, from the lowest: compound 3; then compound 2; then compound 1.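

Measured by this assay, the place on the carbonyl carbon accepts a five-membered aromatic ring with two hetero atoms as well as a six-membered all-carbon ring, and this new group gives the large change of a 25-fold lower number from compound 1 to compound 3 (1.39 log units; beyond the scatter). The two ring-bearing groups are clearly not interchangeable: exchanging one for the other gives a 4.6-fold lower number from compound 2 to compound 3 (0.66 log units; beyond the scatter), so the presence of an aromatic ring alone does not set the number at this place. Nothing available here accounts for the better result with the 5-(tert-butyl)-1,2-oxazol-3-yl group.

That group differs from the earlier ring in ring size, in its hetero atoms and in its substituents all at once, so these compounds cannot show whether the gain follows the ring, the tert-butyl group or the two together. A 1,2-oxazol-3-yl ring carrying methyl in place of tert-butyl would begin to separate these parts, while a cyclohexyl group on the same carbonyl carbon would test whether the ring needs to be aromatic at all.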